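This account rests on a few compounds, and the source may have more. Where it says the series, first, only, none or still open, it means among the compounds named here.

Working notes on the series.

For the measured compounds named here, compound 3 `Cn1cc(-c2ccc(C(F)(F)F)cc2)c2ccc(C(=O)NS(C)(=O)=O)cc21` is the weakest of the three measured members: in an ADME assay on microsomes from liver (Mus musculus) for metabolic stability, with a stated time of 10 min, tested at 0.5 uM (on this read-out higher numbers stand for a more stable compound and lower numbers for a less stable compound), compound 3 gives 54%. Compound 1 `Cn1cc(-c2ccc(C(F)(F)F)cc2)c2ccc(C(=O)NS(=O)(=O)C3CC3)cc21` carries the change cyclopropyl in place of methyl on a sulfonyl sulfur on the same core; in this assay compound 1 gives 87%, a step of a number 33 percentage points higher from compound 3 to compound 1 (beyond the scatter). Compound 2 `CC(C)COc1ccc(-c2cn(C)c3cc(C(=O)NS(C)(=O)=O)c(F)cc23)cn1` sits on a different core, and how the two cores differ is not broken down here; in this assay compound 2 gives 99%, the highest of the three, beyond the scatter from both compound 1 and compound 3.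

Compound 4 `CC(C)COc1ccc(-c2cn(C)c3cc(C(=O)NS(=O)(=O)C4CC4)c(F)cc23)cn1` is not yet measured. It stands to compound 2 as compound 1 stands to compound 3: the change (cyclopropyl in place of methyl on a sulfonyl sulfur), the same change at the same place. The earlier step was large, but compound 2 already gives 99%, close to the top of the scale, so little room remains. The step is expected to be a number 1 percentage points lower from compound 2 to compound 4 (within the scatter), essentially flat. For compound 4 the expected value in this assay is 98%, with a range from 91% to 100%.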

Compound 4, percent of the compound remaining: 98%
The estimate for compound 4 equals the measured number at the digits printed, and the stated range covers the measured number.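

The size of the step from cyclopropyl in place of methyl on a sulfonyl sulfur does not carry from one core to the other in this assay: the same change on two cores in this assay, a number 33 percentage points higher (beyond the scatter) from compound 3 to compound 1 and a number 1 percentage points lower (within the scatter) from compound 2 to compound 4, 34 percentage points apart, beyond the scatter of two such steps

The step of a number 1 percentage points lower from compound 2 to compound 4 (within the scatter) starts close to the top of the scale, where a further rise could hardly be read. The flat result therefore does not show that the change does nothing on this core, only that no gain can be seen there, and two cores in one assay give no general rule for the series.

The compounds shown leave open how ethyl, a longer chain or an amine on the sulfonyl sulfur would read on either core. Also open is which of the differences between the two cores goes with the gap between the steps, as no pair shown changes any of them alone.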